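The source may hold more compounds than are shown below. What is called first, only, known or untested is meant among the compounds shown, and "the series" means these compounds.

Measured so far in an assay on isolated protein for inhibition of 2-Hydroxyacid oxidase 2 (Rattus norvegicus); on this read-out higher numbers stand for weaker inhibition and lower numbers for stronger inhibition:

Compound 1, `Cc1n[nH]c(C(=O)O)c1Cc1cccc(-c2cccc(F)c2)c1`: 500 nM
Compound 2, `Cc1n[nH]c(C(=O)O)c1Cc1cccc(-c2ccc(C(N)=O)cc2)c1`: 200 nM
Compound 3, `Cc1n[nH]c(C(=O)O)c1Cc1ccc(-c2ccc(OC(F)(F)F)cc2)cc1`: 2000 nM

Among these three numbers compound 1 stands second highest. Its nearest neighbour is compound 2, which gives a lower number in this assay, a gap that lies beyond the usual scatter of repeated measurements. Compound 3 gives the highest number of the three, and its gap to compound 1 also lies beyond the scatter. All three compounds share the same core and differ only in what is attached to the aromatic ring that hangs off it.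

The next compound, compound 4, is `Cc1n[nH]c(C(=O)O)c1Cc1cccc(OC(F)(F)F)c1`. Set against compound 1, the change is trifluoromethoxy in place of 3-fluorophenyl on an aromatic carbon. A whole aromatic ring with its fluorine leaves, and a much smaller group takes its place on the same aromatic carbon.

Among the compounds with values here, no pair of measured compounds differs in just one place, so there is no measured step to lean on. What the three numbers do show is that the compounds which keep a second aromatic ring give numbers between those of compound 2 and compound 3. Taking that ring away is a larger change than any seen so far, and the expectation is a step to a higher number in this assay, beyond the scatter, of about a 6.0-fold higher number from compound 1 to compound 4 (0.78 log units; beyond the scatter). For compound 4 the estimate in this assay is 3000 nM, with a likely range from 800 nM to 12000 nM.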

Compound 4, half-maximal inhibitory concentration: 700 nM
Beside the measured number, compound 4's estimate is 4.3-fold (0.63 log units) above it; measured number below the stated range.
By their numbers in this assay, from the lowest: compound 2; then compounds 1 and 4 (each within the scatter of the next); then compound 3.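

In this assay the step is a 1.4-fold higher number from compound 1 to compound 4 (0.15 log units; within the scatter), and because it lies within the usual scatter, the swap of 3-fluorophenyl for trifluoromethoxy on this aromatic carbon cannot be told apart from no change at all in this assay. Compound 1, compound 2 and compound 3 all carry a second aromatic ring, so they could not show what compound 4 now shows: in this one pair, a group with no ring and fewer heavy atoms gives a number on a par with that of the ring-bearing compound, and the second ring is not needed to keep that number. Nothing available explains why these two quite different groups read alike.

Still open, going by these compounds, is whether a smaller or differently built group on this aromatic carbon, such as a plain hydrogen, a methoxy group or an amine, would also give a number close to those of compound 1 and compound 4. A single step also leaves open whether the swap would read the same way from a different ring-bearing partner, such as a phenyl ring carrying a nitrile.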